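Benzyl in Place of Methyl on the Amide of Compound 3

The source may report more compounds than this note shows. Statements on the series, on what has been measured and on what is new or still open speak of the compounds shown alone.

Measured compounds:
Compound 1, `CNC(=O)c1cc(Oc2cccc(NC(=S)Nc3ccc(Cl)cc3)c2)ccn1`, gives 39400 nM in a functional assay on HCT-116 cells (Homo sapiens) for cytotoxicity, read by MTT assay, with a stated time of 48 h; a lower number here means a stronger inhibitor, a higher number a weaker inhibitor.
Compound 2, `O=C(NCc1ccccc1)c1cc(Oc2cccc(NC(=S)Nc3ccc(Cl)cc3)c2)ccn1`, gives 16500 nM in this assay.
Compound 3, `CNC(=O)c1cc(Oc2cccc(NC(=S)Nc3ccc(OC(F)(F)F)cc3)c2)ccn1`, gives 33800 nM in this assay.

Compound 3 sits second highest of the three numbers. Its value and that of compound 1 lie within the scatter of each other, so nothing separates them, whereas compound 2 shows a number lower than that of compound 3 by a gap beyond the scatter.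

Compound 4, `O=C(NCc1ccccc1)c1cc(Oc2cccc(NC(=S)Nc3ccc(OC(F)(F)F)cc3)c2)ccn1`, is not yet measured. It differs from compound 3 in one place: phenyl in place of hydrogen on a saturated chain carbon bound to an amide-type nitrogen.

For the measured compounds named here, one measured step bears on this change, the same replacement made on the chloro-bearing pair: a 2.4-fold lower number from compound 1 to compound 2 (0.38 log units; beyond the scatter). The other measured step, a 1.2-fold lower number from compound 1 to compound 3 (0.07 log units; within the scatter), swaps the ring substituent instead and stayed within the scatter, suggesting that the two ends of the molecule behave much alike. The step to compound 4 is therefore expected to be of similar size and direction in this assay, namely a 2.4-fold lower number from compound 3 to compound 4 (0.38 log units; beyond the scatter). Compound 4 is estimated at 14000 nM, expected between 7000 nM and 30000 nM.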

Compound 4, half-maximal inhibitory concentration: 7400 nM
The estimate for compound 4 lay 1.9-fold (0.28 log units) above the measured number; the measured number falls inside the stated range.
By their numbers in this assay, from the lowest: compound 4; then compound 2; then compounds 3 and 1 (each within the scatter of the next).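

Benzyl in place of methyl on the amide also lowers the number on the trifluoromethoxy-bearing core, with a 4.6-fold lower number from compound 3 to compound 4 (0.66 log units; beyond the scatter), so in this assay this change points the same way with both ring substituents shown: the same change on two cores in this assay, a 2.4-fold lower number (0.38 log units; beyond the scatter) from compound 1 to compound 2 and a 4.6-fold lower number (0.66 log units; beyond the scatter) from compound 3 to compound 4, 1.9-fold (0.28 log units) apart, within the scatter of two such steps. Trifluoromethoxy in place of chloro, which left the methyl amides within the scatter, now gives a gap on the benzyl amides, with a 2.2-fold lower number from compound 2 to compound 4 (0.35 log units; beyond the scatter), yet this step does not clearly differ from the one on the methyl amides: the same change on two cores in this assay, a 1.2-fold lower number (0.07 log units; within the scatter) from compound 1 to compound 3 and a 2.2-fold lower number (0.35 log units; beyond the scatter) from compound 2 to compound 4, 1.9-fold (0.28 log units) apart, within the scatter of two such steps. The two changes may therefore simply add up, and these four compounds give no firm sign that either one strengthens the other.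

Going by these compounds, it remains open whether the phenyl itself matters or any larger group would serve, as a cyclohexyl or a longer chain such as phenylethyl could show. On these data alone, what an amine or a carboxylic acid on that phenyl would do also stays open.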